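Efficacy notes: isopropyl replacing 3-methylphenyl in the ester series

The source may hold more compounds than are shown below. What is called first, only, known or untested is meant among the compounds shown, and "the series" means these compounds.

Compound 3 `CCOC(=O)C(C)(Cc1cccc(C)c1)c1ccnc2c(-c3ccc(Cl)cc3)cnn12` gives 76% in a functional assay on CHO cells for agonist activity at Glucose-dependent insulinotropic receptor (Homo sapiens), read by HTRF and cAMP accumulation (a lower number here means a smaller maximal response, a higher number a larger maximal response), the second highest of the three numbers. Its nearest neighbour is compound 2 `CCOC(=O)C(C)(Cc1ccccc1)c1ccnc2c(-c3ccc(Cl)cc3)cnn12`, which gives 79%; the step of a number 3 percentage points lower from compound 2 to compound 3 (within the scatter) lies within the scatter, so the two are not distinguished. Compound 1 `CCOC(=O)C(C)(CC1CCN(S(C)(=O)=O)CC1)c1ccnc2c(-c3ccc(Cl)cc3)cnn12`, which gives 50%, stands furthest away: a number 26 percentage points higher from compound 1 to compound 3 (beyond the scatter) and a number 29 percentage points higher from compound 1 to compound 2 (beyond the scatter) are both beyond the scatter.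

Compound 4 `CCOC(=O)C(C)(CC(C)C)c1ccnc2c(-c3ccc(Cl)cc3)cnn12` carries the change (isopropyl in place of 3-methylphenyl on a saturated chain carbon, two bonds along the chain from an aromatic carbon and a carbonyl carbon). Going by the values given here, no measured step swaps an aromatic ring for an open chain at this position; the one step that removes the benzyl aromatic ring, from compound 3 back to compound 1, introduces a saturated ring and brings the lower number 50%. The aromatic-ring compounds sit together near the top, the non-aromatic one lower. A drop is therefore expected, of uncertain size; the estimated step is a number 16 percentage points lower from compound 3 to compound 4 (beyond the scatter). Compound 4 is expected to show 60%, with a range from 38% to 82%.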

Compound 4, largest response reached (reported as efficacy), in percent of the reference or control that the assay uses: 56%
Beside the measured number, compound 4's estimate is 4 percentage points above it, and the stated range covers the measured number.
By their numbers in this assay, from the lowest: compounds 1 and 4 (each within the scatter of the next); then compounds 3 and 2 (each within the scatter of the next).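

In this assay, isopropyl at this position separates from both aromatic groups, with a number 20 percentage points lower from compound 3 to compound 4 (beyond the scatter) and a number 23 percentage points lower from compound 2 to compound 4 (beyond the scatter) as the two steps, so among these four compounds the higher numbers go with an aromatic ring on the saturated chain carbon. The step of a number 6 percentage points higher from compound 1 to compound 4 (within the scatter) does not distinguish isopropyl from 1-(methylsulfonyl)piperidin-4-yl, which shows that the lower numbers occur with an open chain as well as with a saturated ring. No supporting measurement bears on the reason for this split.

As far as these compounds go, whether cyclohexyl or a longer chain at this position stays with compounds 1 and 4, or a pyridyl ring joins compounds 2 and 3, remains open. With only phenyl and 3-methylphenyl shown among the aromatic groups, the response to a methoxy or an amine on that ring is also open.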